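Working notes: compound 3 to compound 4

The compounds below may be only part of what the source reports. "The series", "measured", "known", "first", "only" and "open" are said of these compounds alone.

- compound 1 `Cc1ccc(NC(=O)c2cccc(C(F)(F)F)c2)cc1N1Cc2cnc(Nc3ccc(C)c(C(F)(F)F)c3)nc2N(C)C1=O`: > 10000 nM (a limit)
- compound 2 `Cc1ccc(Nc2ncc3c(n2)N(C)C(=O)N(c2cc(NC(=O)c4cccc(C(F)(F)F)c4)ccc2C)C3)cc1N(C)C`: > 10000 nM (a limit)
- compound 3 `Cc1ccc(Nc2ncc3c(n2)N(C)C(=O)N(c2cc(NC(=O)c4cccc(C(F)(F)F)c4)ccc2C)C3)cc1N`: 440 nM

For the measured compounds named here, in an ADME assay on BaF3 cells (Mus musculus) for antiproliferative activity, read by CellTiter-Glo and CCK-8 assay, with a stated time of 72 h (a lower number here means a stronger inhibitor of growth, a higher number a weaker inhibitor of growth), compound 3 gives 440 nM, the only true number in this set. Compound 1 and compound 2 both rest at the limit of > 10000 nM in this assay, at which 2 of the 3 values shown sit.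

Compound 4 `Cc1cccc(C(=O)Nc2ccc(C)c(N3Cc4cnc(Nc5ccc(C)c(N)c5)nc4N(C)C3=O)c2)c1` is the next comparison. The difference is methyl in place of trifluoromethyl on an aromatic carbon. The exchange turns 3-(trifluoromethyl)phenyl into 3-methylphenyl.

Going by the values given here, no measured step makes this exchange. The nearest evidence is an at least 22-fold lower number from compound 1 to compound 3 (1.35 log units; beyond the scatter) and an at least 22-fold lower number from compound 2 to compound 3 (1.35 log units; beyond the scatter), both large and both beyond the scatter. Each concerns a different aromatic carbon from the one changed here, so neither size carries over directly. Among the compounds with values here, they show only that one exchange on the scaffold of compound 3 can move this assay a long way, so the range is kept wide, and it stays short of the limit.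

The expected change is a 2.3-fold higher number from compound 3 to compound 4 (0.36 log units; beyond the scatter), a modest move towards a higher number and weaker inhibition of growth. For compound 4 the estimated value is 1000 nM, with an expected range of 300 nM to 5000 nM.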

Compound 4, concentration for 50% growth inhibition: > 10000 nM
Compound 4: no number, only a limit (the forecaster's own chance of this, stated with the estimate: 12%); at least 10-fold (1.00 log units) between middle value and limit.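

In this assay, the change from 3-(trifluoromethyl)phenyl to 3-methylphenyl gives an at least 22-fold higher number from compound 3 to compound 4 (1.35 log units; beyond the scatter). For the compounds shown here, this is the only step in the set at this position, as the earlier steps all changed a different aromatic carbon, so activity now proves sensitive at two separate places on the scaffold of compound 3. The result for compound 4 is a limit, so the step gives only a minimum size for the loss, and compound 3 remains the sole compound with a true number, while compound 1, compound 2 and compound 4 each differ from it in one place and give none: the limit of > 10000 nM in this assay, at which 3 of the 4 values shown sit.

The compounds shown cover only trifluoromethyl and methyl at this position, so they cannot separate what the exchange acts through, and one pair cannot show whether trifluoromethyl is uniquely required here. A chloro, methoxy or nitrile group on this aromatic carbon, or a longer chain such as ethyl, would test whether any other group keeps a true number in this assay.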